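Swapping nitro for chloro on a thiazolidinedione benzylidene

A few compounds are considered here, and "the series" means these few. Any claim that something is new, unique, unknown or untested is made for them only; others in the source may bear on it.

Measured so far:
- compound 1, `Cc1ccc(CN2C(=O)S/C(=C\c3ccc([N+](=O)[O-])cc3)C2=O)cc1`: 11.4%
- compound 2, `Cc1ccc(CN2C(=O)S/C(=C\c3ccc(O)cc3)C2=O)cc1`: 37.3%

Two compounds share a core and differ only in the group on the aromatic carbon of the benzylidene ring. In a functional assay on the whole organism (plasma) with Mus musculus as the target, with a stated time of 15 days, at a dose of 30 mg/kg by the oral route (on this read-out higher numbers stand for a stronger effect at the one dose given and lower numbers for a weaker effect), compound 1 gives 11.4%, the lower of the two numbers; in this assay compound 2 gives 37.3%. Among the measured compounds shown here, the single measured step, a number 25.9 percentage points higher from compound 1 to compound 2 (beyond the scatter), comes from hydroxy in place of nitro on an aromatic carbon and lies beyond the scatter.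

Compound 3, `Cc1ccc(CN2C(=O)S/C(=C\c3ccc(Cl)cc3)C2=O)cc1`, has not been measured. The change from compound 1 is chloro in place of nitro on an aromatic carbon. For the measured compounds named here, no measured step has chloro entering, so the one step that bears on this at all is the removal of nitro in compound 2, a number 25.9 percentage points higher from compound 1 to compound 2 (beyond the scatter), which went upward. That is only a loose guide, since chloro is not hydroxy. A rise of uncertain size is therefore expected, and the estimated step from compound 1 is a number 10.6 percentage points higher from compound 1 to compound 3 (beyond the scatter). Compound 3 is estimated at 22% in this assay, within a range from 5% to 40%.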

Compound 3, a percentage reported as activity, at one dose (the size of the read-out at that dose, not a potency): 22.8%
The estimate for compound 3 lay 0.8 percentage points below the measured number; low and high end bracket the measured number.
By their numbers in this assay, from the lowest: compound 1; then compound 3; then compound 2.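

Chloro in place of nitro gives a number 11.4 percentage points higher from compound 1 to compound 3 (beyond the scatter) in this assay, so the rise at this ring position does not depend on hydroxy being the group that replaces nitro: chloro, which counts no hydrogen-bond donors or acceptors, also gives a higher number than nitro. Chloro does not match hydroxy, however, since chloro in place of hydroxy gives a number 14.5 percentage points lower from compound 2 to compound 3 (beyond the scatter), and the three groups therefore fall into a clear order, with nitro lowest, chloro in the middle and hydroxy highest, each step lying beyond the usual scatter. Nothing available here gives a reason for this order.

What the compounds shown leave open is how other groups at this same place, such as an amine, a carboxylic acid, methoxy or fluoro, would fall relative to these three. They also leave open whether this order would hold at other doses, as each number comes from a single dose and says nothing about potency.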